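A few compounds are considered here, and "the series" means these few. Any claim that something is new, unique, unknown or untested is made for them only; others in the source may bear on it.

Measured compounds:
Compound 1 `Cc1cccc(-n2nncc2CN2C(=O)C3(C(C#N)=C(N)Oc4c3c3nc5ccccc5nc3c3ccccc43)c3ccccc32)c1` gives > 50000 nM in a functional assay on HCT-116 cells (Homo sapiens) for antiproliferative activity, read by MTT assay, with a stated time of 48 h; on this read-out higher numbers stand for weaker inhibition and lower numbers for stronger inhibition.
Compound 2 `COc1ccc(-n2nncc2CN2C(=O)C3(C(C#N)=C(N)Oc4c3c3nc5ccccc5nc3c3ccccc43)c3ccccc32)cc1` gives > 50000 nM in this assay.
Compound 3 `CCOc1ccc(-n2nncc2CN2C(=O)C3(C(C#N)=C(N)Oc4c3c3nc5ccccc5nc3c3ccccc43)c3ccccc32)cc1` gives > 50000 nM in this assay.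

Each of these three values is a limit of this assay, not a measured number, and all three sit together at the limit of > 50000 nM in this assay, at which 3 of the 3 values shown sit. Compound 3 therefore stands at that limit, and nothing in the numbers separates it from compound 1 or compound 2. The steps among the measured compounds, a step that the two limits leave unreadable from compound 1 to compound 2, a step that the two limits leave unreadable from compound 1 to compound 3 and a step that the two limits leave unreadable from compound 2 to compound 3, cannot be read in size or direction because both ends of each sit at a limit.

Compound 4 `N#CC1=C(N)Oc2c(c3nc4ccccc4nc3c3ccccc23)C12C(=O)N(Cc1cnnn1-c1ccc(N)cc1)c1ccccc12` differs from compound 3 by amino in place of ethoxy on an aromatic carbon. For the measured compounds named here, no measured step bears readably on this change, so no size or direction can be drawn from the data, and the step from compound 3 to compound 4 is expected as a number no higher from compound 3 to compound 4 (the limit leaves the size open), with the result most likely again a limit. Compound 4 is estimated at 50000 nM, within a range from 15000 nM to 200000 nM.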

Compound 4, half-maximal inhibitory concentration: 45200 nM
For compound 4 the middle estimate is 1.1-fold (0.04 log units) above the measured one; low and high end bracket the measured number.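

For the compounds shown here, compound 4 is the one compound here whose value in this assay is a number, 45200 nM, and not a limit. The other three values are limits: the limit of > 50000 nM in this assay, at which 3 of the 4 values shown sit. Amino on the aromatic carbon, para to a large group, gives an at least 1.1-fold lower number from compound 3 to compound 4 (0.04 log units; that floor lies within the scatter), and the comparisons with the other two compounds read an at least 1.1-fold lower number from compound 2 to compound 4 (0.04 log units; that floor lies within the scatter) and an at least 1.1-fold lower number from compound 1 to compound 4 (0.04 log units; that floor lies within the scatter); each of these is only a floor, so the true size of the change remains unknown.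

The steps among compound 1, compound 2 and compound 3 cannot be read, so their aryl groups stay unranked. The compounds shown also leave open whether a hydroxyl, a dimethylamino group or an acetamide at the same place would give a number, and how far that number would lie from the one for compound 4.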